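Trimming a Propyl Chain on Two Inactive Cores

The source may report more compounds than this note shows. Statements on the series, on what has been measured and on what is new or still open speak of the compounds shown alone.

Compound 1 `CCCc1nc(C)c2cnnc(SCC(=O)OCC)n12` and compound 2 `CCOC(=O)CSc1nncc2c(C)nc(C)n12` differ by a single change, (hydrogen in place of ethyl on a saturated chain carbon bound to an aromatic carbon). In a functional assay for inhibition, with Homo sapiens as the target (on this read-out higher numbers stand for weaker inhibition and lower numbers for stronger inhibition), compound 1 reaches only a limit of the assay, > 48000 nM. Compound 2 likewise gives only a limit, > 48000 nM. The step that the two limits leave unreadable from compound 1 to compound 2 cannot be sized because of the limit of > 48000 nM in this assay, at which 3 of the 3 values shown sit. Compound 3 `CCCc1ncn2c(SC)nncc12` carries the same propyl chain on another core; the difference between the two cores is not broken down here. In this assay compound 3 again gives only a limit, > 48000 nM. Going by the values given here, compound 4 `CSc1nncc2c(C)ncn12` has not yet been measured; from compound 3 it differs by hydrogen in place of ethyl on a saturated chain carbon bound to an aromatic carbon, which is the same change as the one between the measured pair. Every value seen so far sits at the limit, so the measured step offers no size to carry over, and the step that the limit leaves unreadable from compound 3 to compound 4 is expected to be essentially flat. Compound 4 is therefore expected to show 60000 nM, most likely reported once more only as a limit rather than a number.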

Compound 4, half-maximal inhibitory concentration: > 48000 nM
Compound 4 ended at the assay's limit; the forecaster's own chance of this, stated with the estimate: 85%; the middle value lies beyond the limit too.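

Compound 3 and compound 4 both stop at a limit of the assay rather than a number, so the step between them cannot be read, just as for the earlier pair: the limit of > 48000 nM in this assay, at which 4 of the 4 values shown sit. The compounds shown leave open whether trimming propyl to methyl changes inhibition at all, and whether any compound on these cores gives a readable value.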